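Removing one chain methyl from compound 2

This account rests on a few compounds, and the source may have more. Where it says the series, first, only, none or still open, it means among the compounds named here.

Compound 1 `CC1=C(CCC(=O)OCCCCOc2no[n+]([O-])c2S(=O)(=O)c2ccccc2)C(=O)c2c(O)cccc2C1=O`: 97.6%
Compound 2 `CC1=C(C(C)CC(=O)OCC(C)COc2no[n+]([O-])c2S(=O)(=O)c2ccccc2)C(=O)c2c(O)cccc2C1=O`: 94.4%

Both values come from a functional assay on MDA-MB-231 cells (Homo sapiens) for inhibition, read by MTT assay, with a stated time of 72 h, tested at 10 uM (a higher number here means more inhibition of growth at the concentration tested, a lower number less inhibition of growth), and lie within the scatter of each other, so compound 2 stands level with compound 1 on the numbers available. Both also sit close to full inhibition of growth.

Still unmeasured is compound 3 `CC1=C(CCC(=O)OCC(C)COc2no[n+]([O-])c2S(=O)(=O)c2ccccc2)C(=O)c2c(O)cccc2C1=O` which departs from compound 2 by one change: hydrogen in place of methyl on a saturated chain carbon bound to a double-bonded ring carbon and a saturated chain carbon. Among the measured compounds shown here, no measured pair isolates this change, so there is no direct precedent for its size. For the measured compounds named here, the only guide is the pair of measured values, compound 2 (94.4%) and compound 1 (97.6%), which show no separation beyond the scatter. An estimated a number 0.6 percentage points higher from compound 2 to compound 3 (within the scatter) is therefore expected in this assay and would stay within the scatter, with no firm direction. The estimate for compound 3 is 95% (expected range 85% to 100%).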

Compound 3, percent growth inhibition at one concentration: 97.4%
Compound 3: the middle estimate sits 2.4 percentage points below what was measured; the range from low to high includes it.
By their numbers in this assay, from the lowest: compounds 2, 3 and 1 (each within the scatter of the next).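

In this assay the change of methyl to hydrogen on a saturated chain carbon bound to a double-bonded ring carbon and a saturated chain carbon gives a number 3 percentage points higher from compound 2 to compound 3 (within the scatter) and is the only step shown that isolates this position. At this single concentration, the series therefore shows no separation between methyl and hydrogen here, but compound 2 and compound 3 both sit close to full inhibition of growth, which leaves the read-out little room to show a gain. No measurement is available that explains the size of this step.

On these data alone, it remains open whether an ethyl, a phenyl or a carboxylic acid at this position would hold growth inhibition at a similar level in this assay or would separate from methyl and hydrogen. As far as these compounds go, it is also open whether methyl and hydrogen would stay level at lower tested concentrations, where values further from full inhibition could reveal a difference that this single-concentration read-out cannot show.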